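Cytotoxicity Outlook for a Cyano Analogue of Compound 2

The compounds below may be only part of what the source reports. "The series", "measured", "known", "first", "only" and "open" are said of these compounds alone.

Two compounds have been measured in an ADME assay on Huh-7 cells (Homo sapiens) for cytotoxicity; a lower number here means that less compound is tolerated, a higher number that more compound is tolerated:

compound 1, `O=C(NC(=S)N1CCc2c(OCCCCCOc3ccc(Cl)cc3)cccc21)c1cccc([N+](=O)[O-])c1`, gives 12100 nM
compound 2, `O=C(NC(=S)N1CCc2c(OCCCCCOc3ccc(Cl)cc3)cccc21)c1ccc([N+](=O)[O-])cc1`, gives 13600 nM

Compound 2 holds the higher of the two numbers in this assay, but its nearest neighbour is compound 1, and the step of a 1.1-fold higher number from compound 1 to compound 2 (0.05 log units; within the scatter) lies within the scatter, so the two values cannot be told apart. Compound 3, `N#Cc1ccc(C(=O)NC(=S)N2CCc3c(OCCCCCOc4ccc(Cl)cc4)cccc32)cc1`, is the next compound to be measured. It differs from compound 2 by cyano in place of nitro on an aromatic carbon. Within the data shown here, no measured step swaps a nitro for a cyano; the only step in hand, a 1.1-fold higher number from compound 1 to compound 2 (0.05 log units; within the scatter), moved the nitro between positions on the same ring and produced no change beyond the scatter. On that evidence no movement beyond the scatter is expected for compound 3, so the step of a 1.0-fold lower number from compound 2 to compound 3 (0.02 log units; within the scatter) is estimated. The value for compound 3 in this assay is thus expected near 13000 nM, with a range from 6000 nM to 28000 nM.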

Compound 3, half-maximal cytotoxic concentration: > 50000 nM
Compound 3: no number, only a limit (the forecaster's own chance of this, stated with the estimate: 10%); middle value at least 3.8-fold (0.58 log units) from the limit.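

In this assay compound 3 gives > 50000 nM, which is a limit of the assay and not a number: the limit of > 50000 nM in this assay, at which 1 of the 3 values shown sits. Exchanging the nitro for a cyano on this aromatic carbon gives an at least 3.6-fold higher number from compound 2 to compound 3 (0.56 log units; beyond the scatter), and the change from 3-nitrophenyl to 4-cyanophenyl gives an at least 4.1-fold higher number from compound 1 to compound 3 (0.61 log units; beyond the scatter). The earlier pair showed only that shifting the nitro around the ring leaves the number within the scatter, whereas these steps show that, in this series, the identity of the group on the ring can move it well beyond the scatter.

On these data alone, how far the true value of compound 3 lies past the limit remains unknown, so both steps have only a lower bound. As far as these compounds go, it also remains open whether an amine or a carboxylic acid in the same place would read like the nitro compounds or like the cyano compound.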